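The source may report more compounds than this note shows. Statements on the series, on what has been measured and on what is new or still open speak of the compounds shown alone.

Series notes. The shared core of compound 1 `Cc1n[nH]c2ccc(-c3nc4cnc(N5CCN(C)CC5)cn4c3Nc3ccc(Cl)cc3)cc12` carries a chloro group on an aromatic carbon and in a functional assay on MV4-11 cells (Homo sapiens) for inhibition, with a stated time of 120 h (a higher number here means a weaker inhibitor, a lower number a stronger inhibitor), compound 1 gives 3510 nM. Compound 2 `Cc1n[nH]c2ccc(-c3nc4cnc(N5CCN(C)CC5)cn4c3Nc3ccc(Br)cc3)cc12` carries bromo in place of chloro and in this assay compound 2 gives 2600 nM; the step of a 1.4-fold lower number from compound 1 to compound 2 (0.13 log units; within the scatter) stays within the scatter. Compound 3 `COc1ccc(Nc2c(-c3ccc4[nH]nc(C)c4c3)nc3cnc(N4CCN(C)CC4)cn23)cc1` carries a methoxyphenyl on the ring nitrogen, and in this assay compound 3 gives "not determined" (no result reported), so compound 3 stands nowhere on the numbers shown.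

Compound 4 `Cc1n[nH]c2ccc(-c3nc4cnc(N5CCN(C)CC5)cn4c3Nc3ccc(Cl)cc3F)cc12` is reached from compound 3 by 4-chloro-2-fluorophenyl in place of 4-methoxyphenyl on a nitrogen on an aromatic ring. Among the measured compounds shown here, no measured step touches this exchange directly: the only measured step, from chloro to bromo, concerns a different swap and was within the scatter, so it neither supports nor contradicts any shift here. Compound 4 shares the chloro group of compound 1 on that ring and adds fluorine; the expectation therefore rests on compound 1 and its value 3510 nM. Compound 4 is estimated at 3500 nM in this assay, with a range from 1200 nM to 10000 nM, the width reflecting the absence of any measured step for the fluorine.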

Compound 4, half-maximal inhibitory concentration: 10400 nM
The estimate for compound 4 lay 3.0-fold (0.47 log units) below the measured number; measured number above the stated range.
By their numbers in this assay, from the lowest: compounds 2 and 1 (each within the scatter of the next); then compound 4.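

In this assay the aryl group on a nitrogen on an aromatic ring proves responsive: fluoro in place of hydrogen on an aromatic carbon gives a 3.0-fold higher number from compound 1 to compound 4 (0.47 log units; beyond the scatter) and the exchange of 4-bromophenyl for 4-chloro-2-fluorophenyl gives a 4.0-fold higher number from compound 2 to compound 4 (0.60 log units; beyond the scatter) on the same nitrogen. Where bromo in place of chloro stayed within the scatter, the added fluorine moves the number beyond it, towards a weaker inhibitor, though only modestly. The exchange of 4-methoxyphenyl for 4-chloro-2-fluorophenyl itself cannot be read, compound 3 having no reported number, and nothing measured here accounts for the rise.

Open, from the compounds shown here alone, is whether a methyl group or an amine in place of that fluorine would move the number the same way. Also open, going by these compounds, is whether in this assay compound 3 would sit with compound 1 or with compound 4.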